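This account rests on a few compounds, and the source may have more. Where it says the series, first, only, none or still open, it means among the compounds named here.

Compound 1 (`Nc1ccc(Oc2ccccc2-c2ccc(S(=O)(=O)NCCNC(=O)Nc3ccc(Cl)cc3)s2)cc1`): 13600 nM
Compound 2 (`COc1cccc(NC(=O)NCCNS(=O)(=O)c2ccc(-c3ccccc3Oc3ccc([N+](=O)[O-])c([N+](=O)[O-])c3)s2)c1`): 1300 nM

In a functional assay on RS4-11 cells (Homo sapiens) for inhibition, read by CCK-8 assay, with a stated time of 48 h (on this read-out lower numbers stand for stronger inhibition and higher numbers for weaker inhibition), compound 2 gives 1300 nM, the lower of the two numbers, while compound 1 gives 13600 nM; this gap lies beyond the usual scatter. Compound 3 (`O=C(NCCNS(=O)(=O)c1ccc(-c2ccccc2Oc2ccc([N+](=O)[O-])c([N+](=O)[O-])c2)s1)Nc1ccc(Cl)cc1`) departs from compound 2 in one place: 4-chlorophenyl in place of 3-methoxyphenyl on an amide-type nitrogen. In words, it carries 4-chlorophenyl in place of 3-methoxyphenyl on an amide-type nitrogen. For the measured compounds named here, compound 1 also carries 4-chlorophenyl, but it differs from compound 2 elsewhere too, and no measured pair isolates this exchange. The data therefore give no firm direction, and no change beyond the scatter is expected. The estimated change is a 1.2-fold lower number from compound 2 to compound 3 (0.07 log units; within the scatter). Compound 3 is expected at 1100 nM, with an estimated range from 350 nM to 4000 nM.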

Compound 3, half-maximal inhibitory concentration: 6700 nM
Estimate against measurement, compound 3: 6.1-fold (0.78 log units) below; measured number above the stated range.
By their numbers in this assay, from the lowest: compound 2; then compound 3; then compound 1.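

In this assay, this amide-type nitrogen proves sensitive to its aryl group: 4-chlorophenyl in place of 3-methoxyphenyl gives a 5.2-fold higher number from compound 2 to compound 3 (0.71 log units; beyond the scatter), a modest step beyond the scatter. The first exchange isolated at the other end of the molecule, 3,4-dinitrophenyl in place of 4-aminophenyl on an oxygen on an aromatic ring, gives a 2.0-fold lower number from compound 1 to compound 3 (0.31 log units; beyond the scatter), so each of the two places separately moves the number, though only modestly. Nothing measured here gives a reason for either step.

The compounds shown do not separate the identity of the ring substituent from its ring position, a question that 3-chlorophenyl or 4-methoxyphenyl on the same nitrogen would address. They also leave open whether 3-methoxyphenyl would lower the number to the same degree alongside 4-aminophenyl on the oxygen.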